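A few compounds are considered here, and "the series" means these few. Any claim that something is new, unique, unknown or untested is made for them only; others in the source may bear on it.

In an ADME assay on HepG2 2.2.15 cells (Homo sapiens) for cytotoxicity (a higher number here means that more compound is tolerated, a lower number that less compound is tolerated), compound 1 `CCC(=O)OCCc1c(-c2ccccc2Cl)c2cc(Cl)ccc2[nH]c1=O` gives 95000 nM and compound 2 `O=C(CCC1CCCCC1)OCCc1c(-c2ccccc2Cl)c2cc(Cl)ccc2[nH]c1=O` gives 160000 nM. Within the data shown here, these are the only two numbers so far, and they lie within the scatter of each other, so neither can be ranked over the other. Compound 3 `CC12CCC(C(=O)OCCc3c(-c4ccccc4Cl)c4cc(Cl)ccc4[nH]c3=O)(OC1=O)C2(C)C` keeps the shared core but changes the group on the carbonyl carbon: a group of 11 heavy atoms (9 carbon, 2 oxygen; one five-membered non-aromatic ring of carbon only, one five-membered non-aromatic ring with 1 hetero atom) in place of a group of 8 heavy atoms (8 carbon; one six-membered non-aromatic ring of carbon only), on a carbonyl carbon. Among the measured compounds shown here, only one measured step bears on this, a 1.7-fold higher number from compound 1 to compound 2 (0.23 log units; within the scatter), where cyclohexyl took the place of hydrogen on the saturated chain. That step stayed within the scatter, but it brought in carbon only, whereas the entering group also holds oxygen, so the evidence is thin. No clear rise or fall is therefore expected in this assay, and the estimate is a 1.3-fold lower number from compound 2 to compound 3 (0.12 log units; within the scatter). Compound 3 is expected to give about 120000 nM, with an estimated range of 50000 nM to 280000 nM.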

Compound 3, half-maximal cytotoxic concentration: > 1800000 nM
Compound 3: only a limit was reported; the forecaster's own chance of this, stated with the estimate: 15%; at least 15-fold (1.17 log units) between middle value and limit.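

Changing the group on the carbonyl carbon can matter a great deal for tolerated concentration: this assay shows an at least 11-fold higher number from compound 2 to compound 3 (1.05 log units; beyond the scatter), and also an at least 18-fold higher number from compound 1 to compound 3 (1.27 log units; beyond the scatter). The value of compound 3 is a limit of the assay, not a number: the limit of > 1800000 nM in this assay, at which 1 of the 3 values shown sits. The only earlier step, a 1.7-fold higher number from compound 1 to compound 2 (0.23 log units; within the scatter), brought in a carbon-only group and stayed within the scatter, whereas the group in compound 3, with oxygen in one of its five-membered rings, is the first shown to go beyond it.

The ring oxygen, the added carbonyl and the two five-membered rings all enter together, and the compounds shown do not separate what each contributes. From the compounds shown here alone, whether an amine or a carboxylic acid in the same place would give a similarly large step also remains open.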